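This account rests on a few compounds, and the source may have more. Where it says the series, first, only, none or still open, it means among the compounds named here.

In a functional assay, read by Griess assay, with a stated time of 150 min, tested at 100 ug/mL (on this read-out higher numbers stand for a stronger effect at the one concentration tested and lower numbers for a weaker effect), compound 1 `O=S(=O)(CC1=NCCO1)c1n[nH]cc1-c1ccccc1` gives 57.5%. Compound 2 `Cc1ccc(-c2c[nH]nc2S(=O)(=O)CC2=NCCS2)cc1` is reported in this assay as "not active" (no number reported), so no number fixes where it stands. Compound 3 `Cc1ccc(-c2c[nH]nc2S(=O)(=O)CC2=NCCO2)cc1` remains to be measured. The change from compound 2 to compound 3 is a group of 5 heavy atoms (3 carbon, 1 nitrogen, 1 oxygen; one five-membered non-aromatic ring with 2 hetero atoms) in place of a group of 5 heavy atoms (3 carbon, 1 nitrogen, 1 sulfur; one five-membered non-aromatic ring with 2 hetero atoms), on a saturated chain carbon bound to a sulfonyl sulfur. Compound 1 carries the entering ring and reads clearly active in this assay, while compound 2 carries the leaving ring and does not. No number exists for compound 2, so the size of the step to compound 3 cannot be set; a rise in this assay beyond the scatter is expected. Compound 3 is expected to give about 40%, within 10% to 65%.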

Compound 3, a percentage reported as activity, at one concentration (the size of the read-out at that concentration, not a potency): 65.2%
Compound 3: middle estimate off by 25.2 percentage points, on the low side; the whole stated range lies below it.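

With the oxygen-containing ring, compound 3 reads as active in this assay, whereas compound 2, with the sulfur-containing ring, is reported as not active, though that step has no number and cannot be read. Methyl in place of hydrogen on an aromatic carbon gives a number 7.7 percentage points higher from compound 1 to compound 3 (within the scatter), so activity with the oxygen-containing ring holds with either substituent. Nothing available explains the difference between the two rings. Open, as far as these compounds go, is how a chlorine or methoxy group on that aromatic carbon would read. From the compounds shown here alone, a six-membered ring or an amine on the saturated chain carbon also remains open.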